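Compound 1 to compound 3: one aryl group exchanged

The source may hold more compounds than are shown below. What is called first, only, known or untested is meant among the compounds shown, and "the series" means these compounds.

Compound 1 (`O=C(Nc1cccc(-n2cc(-c3ccncc3)c(-c3ccc(Cl)c(O)c3)n2)c1)Nc1cccc(C(F)(F)F)c1`) is the starting point in a functional assay on COLO 205 cells (Homo sapiens) for inhibition, read by sulforhodamine B assay, with a stated time of 48 h; on this read-out higher numbers stand for lower toxicity in this test and lower numbers for higher toxicity in this test. In this read-out compound 1 gives > 32500 nM, which is a limit of the assay and not a number. Its standing is therefore (the limit of > 32500 nM in this assay, at which 1 of the 2 values shown sits).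

Compound 2 (`COc1cc(-c2nn(-c3cccc(NC(=O)Nc4cc(C(F)(F)F)cc(C(F)(F)F)c4)c3)cc2-c2ccncc2)ccc1Cl`) gives a measured 2910 nM in this assay. No single change connects compound 2 with compound 1, so the pair gives no step size.

Compound 3 (`O=C(Nc1cccc(-n2cc(-c3ccncc3)c(-c3ccc(Cl)c(O)c3)n2)c1)Nc1ccc(Cl)c(Cl)c1`) differs from compound 1 in one place: 3,4-dichlorophenyl in place of 3-(trifluoromethyl)phenyl on an amide-type nitrogen. Among the compounds with values here, no measured step covers this change, so any expectation for this assay remains loose. Within the data shown here, compound 2 at 2910 nM shows only that a number can be reached. A moderate move towards lower numbers is expected for compound 3, although a second result at the limit would be no surprise. The expected step runs an at least 2.1-fold lower number from compound 1 to compound 3 (0.33 log units; beyond the scatter). For compound 3 the estimate is 15000 nM, with an expected range of 4000 nM to 32500 nM.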

Compound 3, concentration lethal to 50% of the cells: 22700 nM
The estimate for compound 3 lay 1.5-fold (0.18 log units) below the measured number, within the range that was stated.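

Compound 3 gives a measured 22700 nM in this assay, so the aryl group on the amide-type nitrogen is a place where the read-out can become a measured number while the rest of compound 1 stays unchanged. Compound 1 stands at > 32500 nM, which is a limit of the assay and not a number. The exchange of 3-(trifluoromethyl)phenyl for 3,4-dichlorophenyl therefore reads only as an at least 1.4-fold lower number from compound 1 to compound 3 (0.15 log units; that floor lies within the scatter), and its true size stays open because one end of the step is a limit: the limit of > 32500 nM in this assay, at which 1 of the 3 values shown sits.

The compounds shown leave open whether a single chlorine on the aryl ring, as in 3-chlorophenyl or 4-chlorophenyl on the same amide-type nitrogen, would give a number close to that of compound 3 or return to the limit. Also open, as far as these compounds go, is how the read-out responds when the aryl group at this place gives way to a saturated ring such as cyclohexyl, or when the ring carries a dimethylamino group.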